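From phenethyl to 4-fluorophenyl on a sulfur

This account rests on a few compounds, and the source may have more. Where it says the series, first, only, none or still open, it means among the compounds named here.

Compound 1 `COc1ccc(SCc2ccc(C(=O)Nc3ccccc3N)cc2)cc1`: 80.1%
Compound 2 `Nc1ccccc1NC(=O)c1ccc(CSCCc2ccccc2)cc1`: 77.9%

In a functional assay on SMMC-7721 cells (Homo sapiens) for inhibition, read by CCK-8 assay, with a stated time of 72 h, tested at 8 uM (on this read-out higher numbers stand for more inhibition of growth at the one concentration tested and lower numbers for less inhibition of growth), compound 1 gives 80.1% and compound 2 gives 77.9%, two values within the scatter of each other. The next compound to be tested is compound 3 `Nc1ccccc1NC(=O)c1ccc(CSc2ccc(F)cc2)cc1`, which has 4-fluorophenyl in place of phenethyl on a sulfur. Going by the values given here, the only measured step at this place is a number 2.2 percentage points lower from compound 1 to compound 2 (within the scatter), with phenethyl in place of 4-methoxyphenyl on a sulfur. Among the compounds with values here, that single step is thin evidence, and no measured compound yet carries 4-fluorophenyl. Even so, the one exchange seen so far stayed small, so no change beyond the scatter is expected in this assay. The expected size of the change is a number 1.1 percentage points higher from compound 2 to compound 3 (within the scatter). For compound 3 the estimated value is 79%, within a range from 68% to 88%.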

Compound 3, percent growth inhibition at one concentration: 81.9%
For compound 3 the middle estimate is 2.9 percentage points below the measured one, and the stated range covers the measured number.
By their numbers in this assay, from the lowest: compounds 2, 1 and 3 (each within the scatter of the next).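

In this assay, the three groups on the sulfur now give values within the scatter of each other, and the comparison includes both a ring held on a saturated chain and rings joined directly to the sulfur. Placing 4-fluorophenyl in place of phenethyl gives a number 4 percentage points higher from compound 2 to compound 3 (within the scatter), while fluoro in place of methoxy on an aromatic carbon gives a number 1.8 percentage points higher from compound 1 to compound 3 (within the scatter). Neither exchange separates the compounds on this read-out, and no supporting measurement is available to explain these readings.

The compounds shown leave open whether a different group on the sulfur, such as a short chain ending in an amine or a carboxylic acid, would shift the number beyond the scatter. They also leave open whether these three compounds would separate at other concentrations.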